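Series notes: thiophen-2-yl in place of 2,4-difluorophenyl

The source may report more compounds than this note shows. Statements on the series, on what has been measured and on what is new or still open speak of the compounds shown alone.

Measured so far:
compound 1 `CC(C)(C)Cc1c(-c2ccc(F)cc2F)sc(N)c1C(=O)c1ccc(Cl)cc1` — 1%
compound 2 `CC(C)(C)Cc1csc(N)c1C(=O)c1ccc(Cl)c(Cl)c1` — 10%
compound 3 `CC(C)(C)Cc1c(Br)sc(N)c1C(=O)c1cccc(Cl)c1` — 1%

In an assay on CHO cells for displacement of a labelled ligand from adenosine receptor A3 (Homo sapiens), read by scintillation counting, tested at 10 uM (a lower number here means less inhibition, a higher number more inhibition at the concentration tested (going by the name of the read-out)), compound 1 gives 1%. On the numbers shown compound 1 stands level with compound 3 at the digits shown, the two together being the lowest of the three numbers; compound 3 is the nearest to it, with no change at the digits shown, inside the scatter. The furthest is compound 2, whose number in this assay is higher, yet that gap also lies within the scatter. Among the measured compounds shown here, no pair of measured compounds differs in just one place, so no single-step reading is available within the measured set.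

Compound 4 `CC(C)(C)Cc1c(-c2cccs2)sc(N)c1C(=O)c1ccc(Cl)cc1` has not yet been measured in this assay. Against compound 1 the change is thiophen-2-yl in place of 2,4-difluorophenyl on an aromatic carbon. All three measured values sit at the low end of the read-out, and nothing in the measured set tests this particular exchange, so for this assay the step is expected to be small, in no clear direction, and not beyond the scatter. The expected step from compound 1 to compound 4 is a number 3 percentage points higher from compound 1 to compound 4 (within the scatter). For compound 4 in this assay the estimate is 4%, with a range from 0% to 16%.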

Compound 4, a percentage reported as inhibition, at one concentration (the size of the read-out at that concentration, not a potency): 1%
For compound 4 the middle estimate is 3 percentage points above the measured one; the range from low to high includes it.
By their numbers in this assay, from the lowest: compounds 1, 3, 4 and 2 (each within the scatter of the next).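

In this assay, among the compounds shown here, thiophen-2-yl in place of 2,4-difluorophenyl, on the aromatic carbon next to the ring sulfur, gives no change at the digits printed from compound 1 to compound 4 (within the scatter), and this is the only step so far that reads a change at a single place. It shows that at this position, exchanging a six-membered aromatic ring of carbon only, carrying two fluorines, for a five-membered aromatic ring with a sulfur, which also brings in a hydrogen-bond acceptor, does not move the read-out, which stays at the low end for both compounds. No measurement available here bears on why the exchange leaves the read-out unmoved.

As far as these compounds go, whether any group on this carbon can lift the read-out stays open, since both groups compared are aromatic rings, and a morpholine, a carboxylic acid or a longer alkyl chain there would put that to the test. The (4-chlorophenyl)carbonyl group also remains unread as a single change, as compound 2 and compound 3 each differ from compound 1 in more than one place.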